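Compound 3: one more methoxy replaced

The source may hold more compounds than are shown below. What is called first, only, known or untested is meant among the compounds shown, and "the series" means these compounds.

Measured so far in an ADME assay on HepG2 cells (Homo sapiens) for cytotoxicity, read by luminescence, with a stated time of 72 h; on this read-out higher numbers stand for an effect only at larger amounts of compound and lower numbers for an effect already at smaller amounts
compound 1 `CCOC(=O)c1c(-c2cccc(-c3ccccc3)c2)[nH]c2cc(OC)c(OC)cc2c1=O` gives > 21500 nM
compound 2 `CCOC(=O)c1c(-c2cccc(-c3ccccc3)c2)[nH]c2cc(Cl)c(OC)cc2c1=O` gives > 21500 nM

Compound 1 gives > 21500 nM as a limit of this assay and not as a number. Compound 2 gives > 21500 nM as a limit too. The record so far is the limit of > 21500 nM in this assay, at which 2 of the 2 values shown sit, and offers no number for either compound.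

Compound 3 `CCOC(=O)c1c(-c2cccc(-c3ccccc3)c2)[nH]c2cc(OC)c(F)cc2c1=O` differs from compound 1 by fluoro in place of methoxy on an aromatic carbon and carries fluoro in place of methoxy on an aromatic carbon, ortho to a methoxy group.

Among the measured compounds shown here, the only measured step that bears on this is a step that the two limits leave unreadable from compound 1 to compound 2 and it replaces the other methoxy group. With no readable size to carry over, no step beyond the scatter and no direction is expected in this assay here. The expected result is a step that the limit leaves unreadable from compound 1 to compound 3 in this estimate. Compound 3 is estimated at 25000 nM with 12000 nM to 50000 nM as its expected range.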

Compound 3, half-maximal effective concentration: > 21500 nM
Compound 3 ended at the assay's limit (the forecaster's own chance of this, stated with the estimate: 80%); the middle value does not contradict the limit.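

In this assay, among the compounds shown here, compound 3 gives > 21500 nM as a limit and not a number, so no step from compound 1 to compound 3 can be read: the limit of > 21500 nM in this assay, at which 3 of the 3 values shown sit. The compounds shown leave open whether compound 1, compound 2 and compound 3 differ from one another in cytotoxicity at all.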